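A few compounds are considered here, and "the series" means these few. Any claim that something is new, unique, unknown or untested is made for them only; others in the source may bear on it.

In a functional assay on HCT-116 cells (Homo sapiens) for cytotoxicity, read by MTT assay (on this read-out lower numbers stand for stronger inhibition and higher numbers for weaker inhibition), compound 1 (`Nc1ccccc1NC(=O)c1ccc(CNc2nc3ccc(Br)cc3s2)cc1`) gives 400 nM while compound 2 (`Nc1ccccc1NC(=O)c1ccc(CNc2ncc(-c3ccc(Cl)cc3)s2)cc1`) gives 300 nM and compound 3 (`Nc1ccccc1NC(=O)c1ccc(CSc2nc3ccccc3[nH]2)cc1`) stands at 300 nM on the same read-out. Compound 2 is level with compound 3, and its distance to compound 1 lies within the scatter, so these three cannot be told apart.

Compound 4 (`Nc1ccccc1NC(=O)c1ccc(CNc2ncc(Br)s2)cc1`) differs from compound 2 by bromo in place of 4-chlorophenyl on an aromatic carbon with bromo in place of 4-chlorophenyl on an aromatic carbon of a five-membered aromatic ring with 1 nitrogen and 1 sulfur, next to the ring sulfur. Going by the values given here, no measured pair differs in one place, so the data offer no direct precedent for the size of this step. Compound 1 also carries a bromo group and stands at 400 nM with no sign of a large loss, yet a whole aromatic ring leaves here. The expected change is a 2.7-fold higher number from compound 2 to compound 4 (0.43 log units; beyond the scatter) toward weaker inhibition, estimated as moderate. For compound 4 the estimate is 800 nM with an expected range from 250 nM to 2500 nM on repeat measurement.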

Compound 4, half-maximal inhibitory concentration: 400 nM
Compound 4: middle estimate off by 2.0-fold (0.30 log units), on the high side, within the range that was stated.
By their numbers in this assay, from the lowest: compounds 2, 3, 1 and 4 (each within the scatter of the next).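

In this assay, bromo in place of 4-chlorophenyl on an aromatic carbon next to the ring sulfur gives a 1.3-fold higher number from compound 2 to compound 4 (0.12 log units; within the scatter), so the two compounds cannot be told apart. Going by these compounds alone, this is the first single-place comparison, and it shows that one six-membered aromatic ring of carbon can leave this position with no difference beyond the scatter. On this read-out, then, compound 2 does not depend on its 4-chlorophenyl group for its standing relative to compound 4, and nothing at hand gives a reason for this.

Still open, on these data alone, is whether this carbon accepts any group, since an amine, a carboxylic acid or a longer chain there could behave differently from both bromo and 4-chlorophenyl. A bare hydrogen at the same carbon would show whether bromo itself contributes anything.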